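Ethoxy in place of chloro: expected half-life

This account rests on a few compounds, and the source may have more. Where it says the series, first, only, none or still open, it means among the compounds named here.

Measured in an in vitro ADME assay on microsomes (Rattus norvegicus) for metabolic stability; a lower number here means that the compound disappears faster, a higher number that the compound lasts longer:
- compound 1 `CCc1nc(NC(CC)CC)c(Cl)nc1-c1ccc(Cl)cc1Cl`: < 0.0167 h (a limit, not a number)
- compound 2 `CCc1nc(-c2ccc(OC)cc2O)c(CC)nc1NC(CC)CC`: 0.0983 h
- compound 3 `CCC(CC)Nc1nc(C)c(-c2ccc(Cl)cc2Cl)nc1C`: 0.0533 h

Compound 1 stands at the limit of < 0.0167 h in this assay, at which 1 of the 3 values shown sits. This is a limit, so the true half-life of compound 1 is not known. Compound 2 gives 0.0983 h and compound 3 gives 0.0533 h, and these two lie within the usual scatter of each other.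

Compound 4 `CCOc1nc(-c2ccc(Cl)cc2Cl)c(CC)nc1NC(CC)CC` carries ethoxy in place of chloro on an aromatic carbon of the core of compound 1 (ethoxy in place of chloro on an aromatic carbon). No single change has been measured in this series. The expectation therefore rests on compound 2 at 0.0983 h and compound 3 at 0.0533 h, neither of which has a chloro on the shared core. A modest rise in half-life is expected, with an estimated at least 2.3-fold higher number from compound 1 to compound 4 (0.37 log units; beyond the scatter). A result at the limit of this assay remains possible. For compound 4 the estimated half-life is 0.04 h, with an expected range from 0.017 h to 0.1 h.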

Compound 4, half-life: 1.23 h
The estimate for compound 4 lay 31-fold (1.49 log units) below the measured number; the measured number lies above the stated range.
By their numbers in this assay, from the lowest: compounds 3 and 2 (each within the scatter of the next); then compound 4. At a limit, below all of these: compound 1.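

In this assay, the aromatic carbon of the shared core, next to the ring nitrogen and ortho to the (pentan-3-yl)amino group, proves highly sensitive to its substituent: ethoxy in place of chloro gives an at least 73-fold higher number from compound 1 to compound 4 (1.86 log units; beyond the scatter). Compound 2 and compound 3 differ from compound 1 in more than one place, and neither could isolate this position. The step gives a minimum and not an exact size, because compound 1 stands at a limit: the limit of < 0.0167 h in this assay, at which 1 of the 4 values shown sits.

A single replacement cannot separate the loss of chloro from the arrival of ethoxy; methoxy, a longer chain such as propoxy, or an amine on the same carbon would help to divide the two. From the compounds shown here alone, whether ethoxy has a similar effect on other cores remains open.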